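The source may hold more compounds than are shown below. What is called first, only, known or untested is meant among the compounds shown, and "the series" means these compounds.

Measured compounds in an assay on cells for agonist activity at D(4) dopamine receptor (Homo sapiens), read by luminescence and beta-arrestin recruitment, with a stated time of 90 min; on this read-out higher numbers stand for an effect only at larger amounts of compound and lower numbers for an effect already at smaller amounts:
Compound 1 `O=C(CN1CCN(c2ccccn2)CC1)Nc1cccnc1` — compound 1 gives 2660 nM
Compound 2 `Cc1cccc(NC(=O)CN2CCN(c3ncccn3)CC2)c1` — compound 2 gives 278 nM

Among the measured compounds shown here, compound 2 holds the lower of the two numbers; the only other measured compound, compound 1, lies above it by a gap beyond the usual scatter. For the measured compounds named here, compound 1 and compound 2 differ in two places at once, so nothing more than their two values can be said of them together; no single-change step is known.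

Compound 3 `Cc1cccc(NC(=O)CN2CCN(c3ccccn3)CC2)c1` is not yet measured. It differs from compound 2 in one place: pyridin-2-yl in place of pyrimidin-2-yl on an amine nitrogen in a ring. The same pyridin-2-yl group is present in compound 1, but there it is combined with a different amide partner, so the gap between compound 1 and compound 2 cannot be assigned to the ring on the amine nitrogen. Without a measured step of this kind, the step from compound 2 to compound 3 is expected to be a 1.6-fold lower number from compound 2 to compound 3 (0.21 log units; within the scatter), modest and not clearly beyond the scatter, leaning if anything toward a lower number. On that basis the value for compound 3 in this assay is estimated at 170 nM, with a range from 45 nM to 650 nM.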

Compound 3, half-maximal effective concentration: 394 nM
Compound 3: middle estimate off by 2.3-fold (0.37 log units), on the low side, and the stated range covers the measured number.
By their numbers in this assay, from the lowest: compounds 2 and 3 (each within the scatter of the next); then compound 1.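

In this assay, pyridin-2-yl in place of pyrimidin-2-yl on an amine nitrogen in a ring gives a 1.4-fold higher number from compound 2 to compound 3 (0.15 log units; within the scatter), so with 3-methylphenyl on the amide-type nitrogen, this ring change, which takes the hydrogen-bond acceptors of the group from 2 to 1, leaves the read-out unresolved from the usual scatter. Among the compounds shown here, the series also gains its first single-change step on the amide side, where 3-methylphenyl in place of pyridin-3-yl on an amide-type nitrogen gives a 6.8-fold lower number from compound 1 to compound 3 (0.83 log units; beyond the scatter) with pyridin-2-yl held constant, making this the only one of the two steps that lies beyond the scatter. No measurement at hand accounts for either step.

Still open, on these data alone, is whether the pyridin-2-yl and pyrimidin-2-yl groups also stay within the scatter of each other when pyridin-3-yl sits on the amide-type nitrogen, and whether the step on that nitrogen follows the methyl group or the ring nitrogen, a question that a plain phenyl on the amide-type nitrogen would help to separate. Also open, as far as these compounds go, is how far the amine nitrogen in a ring accepts other groups, such as a plain phenyl or a saturated cyclohexyl ring.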